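The source may hold more compounds than are shown below. What is called first, only, known or untested is meant among the compounds shown, and "the series" means these compounds.

Measured compounds and their numbers in an assay on CHO cells for displacement of a labelled ligand from transient receptor potential cation channel subfamily V member 1 (Rattus norvegicus); on this read-out higher numbers stand for weaker inhibition and lower numbers for stronger inhibition:

Compound 1 `Cc1ccc(CC(CNC(=O)C2(c3ccc(NS(C)(=O)=O)cc3)CC2)COC(=O)C(C)(C)C)cc1C`: in this assay compound 1 gives 396 nM.
Compound 2 `C[C@H](C(=O)NC[C@@H](COC(=O)C(C)(C)C)Cc1ccccc1)c1ccc(NS(C)(=O)=O)c(F)c1`: in this assay compound 2 gives 16.5 nM.
Compound 3 `COc1cc(C(C)C(=O)NCC(COC(=O)C(C)(C)C)Cc2ccc(C(C)(C)C)cc2)ccc1NS(C)(=O)=O`: in this assay compound 3 gives 24 nM.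

Among these three, compound 1 has the highest number, so it is the weakest inhibitor of the set; its nearest neighbour is compound 3, whose number is lower by a margin that lies beyond the usual scatter, and compound 2 sits lower still. Compound 2 and compound 3 differ from compound 1 in several places at once, so none of these gaps can be traced to a single change.

Compound 4 `Cc1ccc(CC(CNC(=O)C2(c3ccc(NS(C)(=O)=O)c(F)c3)CC2)COC(=O)C(C)(C)C)cc1C` differs from compound 1 in exactly one place: fluoro in place of hydrogen on an aromatic carbon, so that the 4-(methanesulfonamido)phenyl of compound 1 becomes 3-fluoro-4-(methanesulfonamido)phenyl. Going by the values given here, no pair of measured compounds shows this change on its own, so its effect here is open. Compound 2 does carry this fluoro and gives a low number, but it also carries other changes, so it cannot settle the question. A modest step toward a lower number is expected, a 2.6-fold lower number from compound 1 to compound 4 (0.42 log units; beyond the scatter), only a little beyond the scatter. Compound 4 is therefore estimated at 150 nM, within a range from 50 nM to 500 nM.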

Compound 4, inhibition constant: 1580 nM
Compound 4: the middle estimate sits 11-fold (1.02 log units) below what was measured; measured number outside the range, above it.
By their numbers in this assay, from the lowest: compounds 2 and 3 (each within the scatter of the next); then compound 1; then compound 4.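

In this assay, going by these compounds alone, this is the first clean reading of the change: fluoro in place of hydrogen on an aromatic carbon, ortho to the methanesulfonamido group, gives a 4.0-fold higher number from compound 1 to compound 4 (0.60 log units; beyond the scatter), a modest step that lies beyond the usual scatter. On the core of compound 1, then, this change weakens inhibition rather than strengthening it. It also shows that this position is sensitive, as a single added fluorine atom is enough to move the number measurably. Nothing available here bears on why the number rises.

Going by these compounds, the step comes from one pair, so whether the same fluoro raises the number on other cores stays open, and compound 2, which carries this fluoro but differs from compound 1 in several places, cannot answer that. Also open, on these data alone, is how a different group at this position, such as chloro or a hydroxyl, would compare with hydrogen and with fluoro on the core of compound 1.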